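The source may hold more compounds than are shown below. What is called first, only, known or untested is meant among the compounds shown, and "the series" means these compounds.

Measured so far:
compound 1 `Oc1ccc(O)c(-c2cc(-c3ccc(Cl)cc3)nn2-c2ccccc2)c1` — in a functional assay on cells (Cancer cell lines, Homo sapiens) for cytotoxicity, read by sulforhodamine B assay, with a stated time of 48 h (a higher number here means a weaker inhibitor of growth, a lower number a stronger inhibitor of growth), compound 1 gives 17900 nM
compound 2 `NS(=O)(=O)c1ccc(-n2nc(-c3ccccc3)cc2-c2cc(O)ccc2O)cc1` — in this assay compound 2 gives 86600 nM

Compound 2 stands at the highest of the two numbers; compound 1 sits at a lower number, and that gap is beyond the scatter. These two compounds differ in two places at once, so no single change is isolated between them. Compound 3 `NS(=O)(=O)c1ccc(-n2nc(-c3ccc(Cl)cc3)cc2-c2cc(O)ccc2O)cc1` arises from compound 2 by chloro in place of hydrogen on an aromatic carbon. Among the compounds with values here, no measured pair shows this change on its own. The expected step of a 2.2-fold lower number from compound 2 to compound 3 (0.34 log units; beyond the scatter) is small, toward a lower number, roughly at the edge of the scatter. Compound 3 is therefore estimated at 40000 nM, with a range from 15000 nM to 120000 nM.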

Compound 3, concentration for 50% growth inhibition: 17800 nM
Estimate against measurement, compound 3: 2.2-fold (0.35 log units) above; the measured number falls inside the stated range.
By their numbers in this assay, from the lowest: compounds 3 and 1 (each within the scatter of the next); then compound 2.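

In this assay, within the data shown here, phenyl to 4-chlorophenyl with the sulfamoyl group present is the first isolated change at this position: a 4.9-fold lower number from compound 2 to compound 3 (0.69 log units; beyond the scatter) is a modest step beyond the scatter. The sulfamoyl group, with 4-chlorophenyl present, gives a 1.0-fold lower number from compound 1 to compound 3 (0.00 log units; within the scatter) and stays within the scatter. No data bearing on the cause of either step are available.

On these data alone, whether the chloro step holds without the sulfamoyl group remains open. Also open, as far as these compounds go, is what bromo or methoxy would give at this position, or a carboxylic acid in place of sulfamoyl.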